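Substituted amides at the assay limit

The source may hold more compounds than are shown below. What is called first, only, known or untested is meant among the compounds shown, and "the series" means these compounds.

Measured in a toxicity assay on HepG2 cells (Homo sapiens) for inhibition, read by resazurin assay, with a stated time of 24 h (on this read-out higher numbers stand for lower toxicity in this test and lower numbers for higher toxicity in this test), each value a limit of the assay and not a number:
- Compound 1 `CN(C)C(=O)c1ncc([N+](=O)[O-])[nH]1`: > 100000 nM
- Compound 2 `O=C(NC1CC1)c1ncc([N+](=O)[O-])[nH]1`: > 100000 nM
- Compound 3 `NC(=O)c1ncc([N+](=O)[O-])[nH]1`: > 100000 nM

The three compounds differ only in what sits on the amide nitrogen, yet the numbers do not separate them. The data show (the limit of > 100000 nM in this assay, at which 3 of the 3 values shown sit). Compound 3 therefore has no exact position on this scale, only its limit of > 100000 nM.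

The next structure is compound 4 `O=C(NCCO)c1ncc([N+](=O)[O-])[nH]1`. It carries 2-hydroxyethyl in place of hydrogen on an amide-type nitrogen.

The closest measured comparison at this nitrogen is a step that the two limits leave unreadable from compound 2 to compound 3. Two further comparisons also involve this amide group: a step that the two limits leave unreadable from compound 1 to compound 2 and a step that the two limits leave unreadable from compound 1 to compound 3. None of them gives a size, so none supplies a measured effect to carry over to the new group. They do show that three different amides all reached the limit in this assay, so no step beyond the usual scatter is expected, in either direction.

The expected change is a step that the limit leaves unreadable from compound 3 to compound 4. For compound 4 the estimated value is 150000 nM, with an expected range from 70000 nM to 300000 nM.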

Compound 4, half-maximal cytotoxic concentration: > 100000 nM
Compound 4: a limit, no number (the forecaster's own chance of this, stated with the estimate: 90%); the middle value lies beyond the limit too.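

Compound 4 also gives a limit and not a number, so its steps to compound 1, compound 2 and compound 3 cannot be read, and no size can be stated for any of them: the limit of > 100000 nM in this assay, at which 4 of the 4 values shown sit.

The compounds shown leave open how these four amides rank in this assay, and whether any group on the amide nitrogen would give a measurable value.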